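Chlorination of two aryl cores in Vero cell cytotoxicity

This account rests on a few compounds, and the source may have more. Where it says the series, first, only, none or still open, it means among the compounds named here.

Measured compounds:
compound 1 `N/N=C1\NCCN1c1ccccc1`: 0%
compound 2 `N=c1c(=O)[nH]nc2n1CCN2c1ccccc1`: 26%
compound 3 `N/N=C1\NCCN1c1cccc(Cl)c1`: 0%

In an ADME assay on Vero cells (Chlorocebus sabaeus) for cytotoxicity, with a stated time of 72 h, tested at 10 ug/mL (on this read-out higher numbers stand for a stronger effect at the one concentration tested and lower numbers for a weaker effect), compound 1 gives 0%, and compound 3, which carries chloro in place of hydrogen on an aromatic carbon, gives 0%; the step of no change at the digits printed from compound 1 to compound 3 (within the scatter). Compound 2 gives 26% in this assay, the highest of the three numbers, with the gap to compound 1 and to compound 3 beyond the scatter; how its core differs from that of compound 1 is not broken down here. Compound 4 `N=c1c(=O)[nH]nc2n1CCN2c1ccc(Cl)cc1` carries chloro in place of hydrogen on an aromatic carbon. Compared with compound 3, this is the same kind of change, yet the place differs: in compound 3 the chloro sits meta to a group of 7 heavy atoms, in compound 4 para to a large group. Because no change at the digits printed from compound 1 to compound 3 (within the scatter), the step of a number 1 percentage points higher from compound 2 to compound 4 (within the scatter) is expected to be small. Compound 4 is therefore estimated at 27% in this assay, between 10% and 46%.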

Compound 4, a percentage reported as inhibition, at one concentration (the size of the read-out at that concentration, not a potency): 0%
Compound 4: the middle estimate sits 27 percentage points above what was measured; measured number below the stated range.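

In this assay, chloro in place of hydrogen on an aromatic carbon of the second core comes with a number 26 percentage points lower from compound 2 to compound 4 (beyond the scatter). This change therefore does not carry over as one fixed step between the two cores in this series: the same change on two cores in this assay, no change at the digits printed (within the scatter) from compound 1 to compound 3 and a number 26 percentage points lower (beyond the scatter) from compound 2 to compound 4, 26 percentage points apart, beyond the scatter of two such steps

This does not show what sets the two steps apart, as the chloro stands at a different place in each pair, and compound 1 already gives 0%, leaving no room to read a fall on that core. Going by these compounds, it remains open how chloro would behave at one matching place on both cores. On these data alone, how a methoxy group, an amine or a carboxylic acid on the same ring would read on either core also remains open.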